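This account rests on a few compounds, and the source may have more. Where it says the series, first, only, none or still open, it means among the compounds named here.

Measured in a functional assay on HT-29 cells (Homo sapiens) for antiproliferative activity, read by sulforhodamine B assay, with a stated time of 48 h; a higher number here means a weaker inhibitor, a lower number a stronger inhibitor:
Compound 1 `Cc1ccccc1NS(=O)(=O)c1ccc(N2CCNC2=O)cc1` gives 200 nM.
Compound 2 `O=C1NCCN1c1ccc(S(=O)(=O)Nc2ccc(OC(F)F)cc2)cc1` gives 650 nM.
Compound 3 `CCCCCCOc1ccc(NS(=O)(=O)c2ccc(N3CCNC3=O)cc2)cc1` gives only a limit of the assay, > 1000 nM.

Compound 1 holds the lowest of the two numbers; its nearest neighbour is compound 2, whose number lies higher by more than the scatter. The only one-place step among these compounds, an at least 1.5-fold higher number from compound 2 to compound 3 (0.18 log units; that floor lies within the scatter), ends at the limit of > 1000 nM in this assay, at which 1 of the 3 values shown sits, and concerns a substituent on an oxygen, not the sulfonamide nitrogen, so it says nothing direct about the present change. Compound 4 `O=C1NCCN1c1ccc(S(=O)(=O)Nc2cccc(Cl)c2)cc1` differs from compound 1 by 3-chlorophenyl in place of 2-methylphenyl on a sulfonamide nitrogen. Without a measured step covering this change, compound 4 is expected to stay close, with an expected step of a 1.5-fold higher number from compound 1 to compound 4 (0.18 log units; within the scatter) and an estimated 300 nM, from 100 nM to 900 nM.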

Compound 4, half-maximal inhibitory concentration: 55 nM
Estimate against measurement, compound 4: 5.5-fold (0.74 log units) above; the whole stated range lies above it.
By their numbers in this assay, from the lowest: compound 4; then compound 1; then compound 2. At a limit, above all of these: compound 3.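

Read in this assay the swap of 2-methylphenyl for 3-chlorophenyl on a sulfonamide nitrogen gives a 3.6-fold lower number from compound 1 to compound 4 (0.56 log units; beyond the scatter) and is the first one-place step shown at this nitrogen, so it shows that the number responds to the aryl group there. The two groups have the same count of heavy atoms and no hydrogen-bond donors or acceptors. Nothing measured here gives a cause for this step. From the compounds shown here alone, whether the chlorine or the loss of the methyl carries the step stays open. So does how 3-methylphenyl, 2-chlorophenyl or an amine-bearing phenyl would read here.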